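The source may hold more compounds than are shown below. What is called first, only, known or untested is meant among the compounds shown, and "the series" means these compounds.

Compound 1 `C#CCSc1nc(Sc2nccs2)c(C#N)c(-c2ccc(Cl)cc2)n1`: 6040 nM
Compound 2 `C#CCSc1nc(Sc2nccs2)c(C#N)c(-c2ccc(C)cc2)n1`: 2450 nM

Both values come from a functional assay on SMMC-7721 cells (Homo sapiens) for antiproliferative activity, read by MTT assay, with a stated time of 72 h; a lower number here means a stronger inhibitor, a higher number a weaker inhibitor. Of the two numbers, compound 2 holds the lower, at 2450 nM. Among the measured compounds shown here, the only measured step, a 2.5-fold lower number from compound 1 to compound 2 (0.39 log units; beyond the scatter), is modest and exchanges chloro for methyl on an aromatic carbon.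

Compound 3 `C#CCSc1nc(Sc2nccs2)c(C#N)c(-c2ccc[nH]2)n1` has 1H-pyrrol-2-yl in place of 4-methylphenyl on an aromatic carbon of a six-membered aromatic ring with 2 nitrogen, ortho to a cyano group: 1H-pyrrol-2-yl in place of 4-methylphenyl on an aromatic carbon. For the measured compounds named here, this is a larger exchange than the one between the measured pair, since the whole 4-methylphenyl group leaves. The step to compound 2, a 2.5-fold lower number from compound 1 to compound 2 (0.39 log units; beyond the scatter), therefore bears on it only loosely, as a rough guide to how far the numbers may move. Going by the values given here, no measured compound carries a 1H-pyrrol-2-yl group, so the data fix no direction. A small lean towards a weaker inhibitor is assumed, because compound 2 sits lowest at 2450 nM. The expected change is a 1.6-fold higher number from compound 2 to compound 3 (0.21 log units; within the scatter), and this estimate is uncertain. For compound 3 the estimated value is 4000 nM, with an expected range of 1200 nM to 13000 nM.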

Compound 3, half-maximal inhibitory concentration: > 20000 nM
Compound 3 was reported as a limit (the forecaster's own chance of this, stated with the estimate: 5%); middle value at least 5.0-fold (0.69 log units) from the limit.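

In this assay, this position responds far more strongly to replacing the whole ring than the earlier pair suggested: 1H-pyrrol-2-yl in place of 4-methylphenyl gives an at least 8.1-fold higher number from compound 2 to compound 3 (0.91 log units; beyond the scatter), and in place of 4-chlorophenyl it gives an at least 3.3-fold higher number from compound 1 to compound 3 (0.51 log units; beyond the scatter). The earlier pair had shown only what an exchange on the six-membered ring does, a 2.5-fold lower number from compound 1 to compound 2 (0.39 log units; beyond the scatter), whereas both new steps remove that ring and lie beyond the scatter, so this ring exchange costs activity whichever of the two phenyl groups it replaces. Compound 3 is given only as a limit, not as a number, so both new steps are open-ended: the limit of > 20000 nM in this assay, at which 1 of the 3 values shown sits.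

The exchange brings in a five-membered ring and a hydrogen-bond donor together, and the compounds shown do not separate the two. As far as these compounds go, it remains open how a 1-methylpyrrol-2-yl or a thiophen-2-yl group would read at this position, and whether an unsubstituted phenyl or a methoxy group on the phenyl ring would keep or extend the activity of compound 2.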